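Aryl Replaces Phenethyl on the Dichlorophenyl Core

The compounds below may be only part of what the source reports. "The series", "measured", "known", "first", "only" and "open" are said of these compounds alone.

Compound 1 `Cc1cc(F)ccc1-c1cc(Cl)cc(Cl)c1/C=C/[C@@H]1C[C@@H](O)CC(=O)O1`: 36 nM
Compound 2 `O=C1C[C@H](O)C[C@@H](/C=C/c2c(Cl)cc(Cl)cc2CCc2ccccc2)O1`: 430 nM

In an assay for inhibition of 3-hydroxy-3-methylglutaryl-coenzyme A reductase (Rattus norvegicus) (on this read-out lower numbers stand for stronger inhibition and higher numbers for weaker inhibition), compound 2 holds the higher of the two numbers shown; its only neighbour is compound 1, reached by a 12-fold higher number from compound 1 to compound 2 (1.08 log units; beyond the scatter). Compound 3 `O=C1C[C@H](O)C[C@@H](/C=C/c2c(Cl)cc(Cl)cc2-c2ccc(Cl)c(Cl)c2)O1` is compound 2 with 3,4-dichlorophenyl in place of phenethyl on an aromatic carbon. Within the data shown here, the one measured step bears directly on this change in reverse: a 12-fold higher number from compound 1 to compound 2 (1.08 log units; beyond the scatter) went with phenethyl replacing a six-membered aromatic ring, so putting an aromatic ring back in place of phenethyl is expected to lower the number by a comparable amount. Compound 3 is therefore estimated at 50 nM in this assay, within 15 nM to 160 nM, an expected step of an 8.6-fold lower number from compound 2 to compound 3 (0.93 log units; beyond the scatter).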

Compound 3, half-maximal inhibitory concentration: 25 nM
Compound 3: middle estimate off by 2.0-fold (0.30 log units), on the high side; low and high end bracket the measured number.
By their numbers in this assay, from the lowest: compounds 3 and 1 (each within the scatter of the next); then compound 2.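

Phenethyl and 3,4-dichlorophenyl each carry 8 heavy atoms and one six-membered aromatic ring, yet exchanging them gives a 17-fold lower number from compound 2 to compound 3 (1.24 log units; beyond the scatter) in this assay, so the advantage of an aryl group on this aromatic carbon holds for a second aryl group. The two aryl groups are not separated, with a 1.4-fold lower number from compound 1 to compound 3 (0.16 log units; within the scatter). No measurement shown here explains these differences. Going by these compounds, it remains open whether a benzyl group, a longer chain, or a phenyl ring bearing an amine or a carboxylic acid would fit this position equally well.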